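This account rests on a few compounds, and the source may have more. Where it says the series, first, only, none or still open, it means among the compounds named here.

Measured in an ADME assay on L6 cells (Rattus norvegicus) for cytotoxicity, read by resazurin assay, with a stated time of 72 h; a lower number here means a stronger inhibitor, a higher number a weaker inhibitor:
- compound 1 `OC(c1ccc(Cl)cc1)(c1cccnc1)c1ccc(Cl)cc1F`: 59400 nM
- compound 2 `CC(C)c1ccc(C(O)(c2ccc(C(F)(F)F)cc2)c2cccnc2)cc1`: 56300 nM
- compound 3 `OC(c1ccc(Cl)cc1)(c1cccnc1)c1ccc(F)cc1F`: 70200 nM

Compound 3 gives 70200 nM, and this cannot be told apart from the values of compound 1 and compound 2, since all three lie within the scatter of one another.

The next structure, compound 4 `CC(C)Oc1ccc(C(O)(c2ccc(Cl)cc2)c2cccnc2)c(F)c1`, carries one change from compound 3: isopropoxy in place of fluoro on an aromatic carbon. This is isopropoxy in place of fluoro on an aromatic carbon, para to a large group and meta to a fluoro group.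

Going by the values given here, one measured step touches this same carbon: a 1.2-fold higher number from compound 1 to compound 3 (0.07 log units; within the scatter). It is small, but it only puts fluoro in place of chloro, so it is a limited guide to a much larger group. Among the compounds with values here, no measured compound carries isopropoxy. Compound 2, with its isopropyl group, gives 56300 nM, which offers modest support for expecting little change.

The expected result is a 1.4-fold lower number from compound 3 to compound 4 (0.15 log units; within the scatter), so no clear shift beyond the scatter is anticipated in this assay. For compound 4 the estimated value is 50000 nM, with an expected range of 20000 nM to 100000 nM.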

Compound 4, half-maximal inhibitory concentration: 58200 nM
For compound 4 the middle estimate is 1.2-fold (0.07 log units) below the measured one, and the stated range covers the measured number.
By their numbers in this assay, from the lowest: compounds 2, 4, 1 and 3 (each within the scatter of the next).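

In this assay the step of a 1.2-fold lower number from compound 3 to compound 4 (0.08 log units; within the scatter) replaces a single fluoro atom with isopropoxy, a group of four heavy atoms that brings in an oxygen, and it stays within the scatter, so this carbon accepts a much larger group without a readable change in the number. Placing isopropoxy on the same carbon in place of chloro gives a 1.0-fold lower number from compound 1 to compound 4 (0.01 log units; within the scatter) and also stays within the scatter, so fluoro, chloro and isopropoxy cannot be told apart here. No supporting measurement is available to explain this result.

On these data alone, whether the number stays this flat with an amine or a carboxylic acid on this carbon remains open. A longer chain joined through the same oxygen is also untested among the compounds shown.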